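Indole for tert-butylphenyl on a shared core

The source may report more compounds than this note shows. Statements on the series, on what has been measured and on what is new or still open speak of the compounds shown alone.

Measured compounds:
compound 1, `Cn1ccc2cc(-c3cc4nccc(-c5ccc(F)cc5)n4n3)ccc21`: 2160 nM
compound 2, `COc1cc(-c2ccnc3cc(-c4ccc(C(C)(C)C)cc4)nn23)cc(OC)c1OC`: > 10000 nM

The two measured compounds carry different groups at both variable positions of the shared core. In a functional assay on HCT-116 cells (Homo sapiens) for inhibition, read by CCK-8 assay, with a stated time of 48 h (a higher number here means a weaker inhibitor, a lower number a stronger inhibitor), compound 1 gives 2160 nM. For compound 2 the result is only a limit of this assay, > 10000 nM, so no number is known for it; it sits at the limit of > 10000 nM in this assay, at which 1 of the 2 values shown sits.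

Compound 3, `COc1cc(-c2ccnc3cc(-c4ccc5c(ccn5C)c4)nn23)cc(OC)c1OC`, has not yet been measured. It keeps the trimethoxyphenyl part of compound 2 and changes the other group: 1-methyl-1H-indol-5-yl in place of 4-(tert-butyl)phenyl on an aromatic carbon. Within the data shown here, because compound 2 rests at the limit of > 10000 nM in this assay, at which 1 of the 2 values shown sits, no measured step for this exchange exists, and the value of compound 1 only shows that the 1-methyl-1H-indol-5-yl group is compatible with measurable inhibition in a different setting.

Compound 3 is therefore expected to fall near the limit, with a step of an at least 1.6-fold lower number from compound 2 to compound 3 (0.22 log units; that floor lies within the scatter) pointing toward somewhat stronger inhibition than the limit of compound 2. The estimated value for compound 3 is 6000 nM, within 1500 nM to 20000 nM.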

Compound 3, half-maximal inhibitory concentration: 39 nM
Compound 3: the middle estimate sits 150-fold (2.19 log units) above what was measured; measured number outside the range, below it.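

In this assay, the position on an aromatic carbon of a five-membered aromatic ring with 2 nitrogen proves highly sensitive to the group it carries: with the trimethoxyphenyl part held constant, 1-methyl-1H-indol-5-yl in place of 4-(tert-butyl)phenyl gives an at least 250-fold lower number from compound 2 to compound 3 (2.40 log units; beyond the scatter). This size is only a floor, since compound 2 stands at a limit of the assay and has no number: the limit of > 10000 nM in this assay, at which 1 of the 3 values shown sits. The leaving and entering groups hold the same number of heavy atoms, so that count alone does not separate the two results.

The compounds shown leave open whether the gain depends on the indole ring nitrogen or its methyl, which a naphthyl group or an indole carrying hydrogen in place of that methyl would help to separate. Among these compounds, they also leave open how much the trimethoxyphenyl part contributes beside the indole group, as compound 1, with the same indole group but a 4-fluorophenyl partner, gives 2160 nM, while compound 3 gives 39 nM, and no step between these two can be read here.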